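Hydroxy for Isopropyl at the Side Chain Carbon

This account rests on a few compounds, and the source may have more. Where it says the series, first, only, none or still open, it means among the compounds named here.

Of the compounds shown here, two have been measured in a functional assay on the whole organism with Mus musculus as the target, with a stated time of 90 min, at a dose of 25 umol/kg by the oral route; a lower number here means a weaker effect, a higher number a stronger effect of the compound at the dose given. Compound 1 `O=C(CN(c1nc(Cl)nc2c1ncn2C1CCCCO1)C1CC1)N[C@@H](CCC(=O)OCc1ccccc1)C(=O)OCc1ccccc1` gives 25.2% in this assay, and compound 2 `CC(C)C[C@H](NC(=O)CN(c1nc(Cl)nc2c1ncn2C1CCCCO1)C1CC1)C(=O)OCc1ccccc1` gives 28.2%. Among the measured compounds shown here, the one step between them, a number 3 percentage points higher from compound 1 to compound 2 (within the scatter), leaves the two values within the scatter of each other, so compound 2 stands level with compound 1 rather than apart from it.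

Compound 3 `O=C(CN(c1nc(Cl)nc2c1ncn2C1CCCCO1)C1CC1)N[C@@H](CO)C(=O)OCc1ccccc1` is the next compound for this assay. It differs from compound 2 by hydroxy in place of isopropyl on a saturated chain carbon, two bonds along the chain from an amide-type nitrogen and a carbonyl carbon. For the measured compounds named here, the only measured step touches the same saturated chain carbon, and that step, a number 3 percentage points higher from compound 1 to compound 2 (within the scatter), stayed within the scatter; nothing measured speaks for a move beyond it when hydroxy enters. Compound 3 is therefore expected to sit close to compound 2, with an estimated step of a number 2.2 percentage points lower from compound 2 to compound 3 (within the scatter). The estimate for compound 3 is 26%, between 10% and 42%.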

Compound 3, a percentage reported as activity, at one dose (the size of the read-out at that dose, not a potency): 32.2%
Beside the measured number, compound 3's estimate is 6.2 percentage points below it; the measured number falls inside the stated range.
By their numbers in this assay, from the lowest: compounds 1, 2 and 3 (each within the scatter of the next).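

In this assay, the saturated chain carbon has now carried three different groups, and the exchange of isopropyl for hydroxy (a number 4 percentage points higher from compound 2 to compound 3 (within the scatter)) stays within the scatter, as does the exchange of (benzyloxycarbonyl)methyl for hydroxy (a number 7 percentage points higher from compound 1 to compound 3 (within the scatter)). Hydroxy has 1 heavy atom where isopropyl has 3, and it brings a hydrogen-bond donor and acceptor where isopropyl has neither, yet at this dose the read-out does not separate compounds 1, 2 and 3. No evidence at hand bears on why these values lie as they do.

Going by these compounds, it remains open whether any group at this carbon can move the read-out beyond the scatter, for instance an amine, a carboxylic acid or a longer chain. The three compounds also leave open whether the level values would hold with the benzyl ester changed.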